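This account rests on a few compounds, and the source may have more. Where it says the series, first, only, none or still open, it means among the compounds named here.

Compound 1 `COc1ccc(Cl)cc1C(C)NC(=O)NS(=O)(=O)c1ccccc1`: in a functional assay on thoracic aorta (Rattus norvegicus, strain Wistar), with a stated time of 15 min (a higher number here means that more compound is needed for the effect, a lower number that less compound is needed), compound 1 gives > 300000 nM, which is a limit of the assay.
Compound 2 `COc1ccc(Br)cc1C(C)NC(=O)NS(=O)(=O)c1ccccc1`: in this assay compound 2 gives > 300000 nM, also a limit.
Compound 3 `COc1ccc(Cl)cc1C(C)NC(=O)NS(=O)(=O)c1ccc(C)cc1`: in this assay compound 3 gives > 300000 nM, also a limit.

Compound 1 thus stands only at a limit in this assay, and the other two measured compounds share that position: the limit of > 300000 nM in this assay, at which 3 of the 3 values shown sit. Compound 4 `CCOc1ccc(Cl)cc1C(C)NC(=O)NS(=O)(=O)c1ccccc1` differs from compound 1 by methyl in place of hydrogen on a saturated chain carbon bound to an oxygen on an aromatic ring. Within the data shown here, two measured steps start from compound 1, a step that the two limits leave unreadable from compound 1 to compound 2 and a step that the two limits leave unreadable from compound 1 to compound 3; neither has a readable size, and neither touches the saturated chain carbon bound to an oxygen on an aromatic ring, so no measured step bears directly on this change. With every value of the set sitting at the same limit, the expected result for compound 4 is that same limit, an expected step of a number no higher from compound 1 to compound 4 (the limit leaves the size open). Compound 4 is estimated at 300000 nM, within 100000 nM to 1000000 nM, most probably reported as a limit alone.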

Compound 4, half-maximal effective concentration: > 300000 nM
Compound 4: only a limit was reported; the forecaster's own chance of this, stated with the estimate: 80%; the middle value lies on the limit itself.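

Among these compounds, compound 1 and compound 4 both stand at a limit, so no step between them can be read, and the same holds across the set: the limit of > 300000 nM in this assay, at which 4 of the 4 values shown sit. The compounds shown leave open what any of these changes does in this assay, since none gives a number.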